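The compounds below may be only part of what the source reports. "The series", "measured", "known", "first", "only" and "open" are said of these compounds alone.

Measured so far in a functional assay for inhibition, with Rattus norvegicus as the target, at pH 7.35; a lower number here means a stronger inhibitor, a higher number a weaker inhibitor:
- compound 1 `CCCCOC(=O)C(=O)C(CC)NC(=O)C(CC(C)C)NC(=O)OCc1ccccc1`: 28000 nM
- compound 2 `CCOC(=O)C(=O)C(CC)NC(=O)C(CC(C)C)NC(=O)CCc1ccccc1`: 20000 nM
- compound 3 `CCCCC(NC(=O)C(CC(C)C)NC(=O)OCc1ccccc1)C(=O)C(=O)OCC`: 150000 nM

Compound 1, at 28000 nM, sits within the usual scatter of compound 2, at 20000 nM. Compound 3 gives a clearly higher number, 150000 nM, which marks it as the weaker inhibitor of the set. Compound 1 therefore stands in the stronger part of this small series.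

The next compound to be tested is compound 4 `CCC(NC(=O)C(CC(C)C)NC(=O)OCc1ccccc1)C(=O)C(=O)NCC1CCCCC1`. It keeps the core of compound 1 and changes one group, on a carbonyl carbon: (cyclohexylmethyl)amino in place of butoxy on a carbonyl carbon. In words, (cyclohexylmethyl)amino takes the place of butoxy.

For the measured compounds named here, no two measured compounds differ in only one place, so the data offer no direct guide to this swap. The best available anchor is compound 1 at 28000 nM, so no change beyond the scatter is expected, and the estimated step reads a 1.4-fold lower number from compound 1 to compound 4 (0.15 log units; within the scatter). The uncertainty remains wide. For compound 4 the expected value is 20000 nM, with an estimated range from 5000 nM to 80000 nM.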

Compound 4, half-maximal inhibitory concentration: 66000 nM
Compound 4: middle estimate off by 3.3-fold (0.52 log units), on the low side, and the stated range covers the measured number.
By their numbers in this assay, from the lowest: compounds 2 and 1 (each within the scatter of the next); then compound 4; then compound 3.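

In this assay, for the compounds shown here, putting (cyclohexylmethyl)amino in place of butoxy on this carbonyl carbon gives a 2.4-fold higher number from compound 1 to compound 4 (0.37 log units; beyond the scatter), the first step in which only one place changes. This shows that the group on this carbonyl carbon can shift the number beyond the usual scatter, although the step is modest and rests on this single pair. No measured evidence bears on the reason for the shift, so it cannot be assigned to the incoming nitrogen, its hydrogen-bond donor or the ring.

The compounds shown leave open whether the ring or the nitrogen matters more, a question that butylamino or cyclohexylmethoxy on the same carbonyl carbon could help to settle. A free carboxylic acid at this position also remains an open case.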